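Moving the ring nitrogen in an ester side chain

The source may hold more compounds than are shown below. What is called first, only, known or untested is meant among the compounds shown, and "the series" means these compounds.

Measured compounds:
Compound 1 `COc1nc(C)c(Nc2nc(Cl)cn([C@H](CO)C3CC3)c2=O)cc1C` — in an assay on frontal cortex for displacement of a labelled ligand from corticotropin-releasing factor receptor 1 (Rattus norvegicus), with a stated time of 2 h (on this read-out lower numbers stand for stronger inhibition and higher numbers for weaker inhibition), compound 1 gives 88 nM
Compound 2 `COc1nc(C)c(Nc2nc(Cl)cn([C@H](COC(=O)c3ccccc3)C3CC3)c2=O)cc1C` — compound 2 gives 1.5 nM
Compound 3 `COc1nc(C)c(Nc2nc(Cl)cn([C@H](COC(=O)c3ccccn3)C3CC3)c2=O)cc1C` — compound 3 gives 67 nM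

Compound 2 has the lowest number of the three. The other two lie well away: the step from compound 2 to compound 3 is a 45-fold higher number from compound 2 to compound 3 (1.65 log units; beyond the scatter), and compound 1 stands further still, as a 59-fold lower number from compound 1 to compound 2 (1.77 log units; beyond the scatter) shows. The next compound, compound 4 `COc1nc(C)c(Nc2nc(Cl)cn([C@H](COC(=O)c3cccnc3)C3CC3)c2=O)cc1C`, changes compound 2 at one place: pyridin-3-yl in place of phenyl on a carbonyl carbon.

Among the compounds with values here, two measured steps bear on this. Adding the benzoyl ester gave a 59-fold lower number from compound 1 to compound 2 (1.77 log units; beyond the scatter), a large gain, while the pyridin-2-yl ester gave only a 1.3-fold lower number from compound 1 to compound 3 (0.12 log units; within the scatter) over compound 1, so almost all of that gain was lost when a nitrogen entered the ring, as a 45-fold higher number from compound 2 to compound 3 (1.65 log units; beyond the scatter). Whether a nitrogen at the other position behaves the same way is not shown by any measured compound.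

An intermediate outcome is therefore expected for compound 4: an 8.0-fold higher number from compound 2 to compound 4 (0.90 log units; beyond the scatter), a weaker binder than compound 2 but not as weak as compound 3, with an estimated 12 nM in this assay, ranging from 2.5 nM to 60 nM.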

Compound 4, half-maximal inhibitory concentration: 5.2 nM
The estimate for compound 4 lay 2.3-fold (0.36 log units) above the measured number, and the stated range covers the measured number.
By their numbers in this assay, from the lowest: compound 2; then compound 4; then compounds 3 and 1 (each within the scatter of the next).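

In this assay, the position of the ring nitrogen decides how much of the gain from the ester survives: replacing phenyl with pyridin-3-yl brings only a modest loss (a 3.5-fold higher number from compound 2 to compound 4 (0.54 log units; beyond the scatter)), while exchanging pyridin-2-yl for pyridin-3-yl brings a large improvement (a 13-fold lower number from compound 3 to compound 4 (1.11 log units; beyond the scatter)). A nitrogen in this ring therefore does not by itself cancel the gain, and the (pyridin-3-yl)carbonyl group still gives a large improvement over hydrogen on the same oxygen (a 17-fold lower number from compound 1 to compound 4 (1.23 log units; beyond the scatter)). Nothing measured here explains why the two pyridine isomers differ so much.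

The compounds shown leave open how a thiophene or cyclohexyl ring on the carbonyl carbon would compare. They also leave open whether an amide in place of the ester would keep the gain.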